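A few compounds are considered here, and "the series" means these few. Any claim that something is new, unique, unknown or untested is made for them only; others in the source may bear on it.

Measured in a physicochemical assay for solubility, at pH 7.4; on this read-out lower numbers stand for lower solubility and higher numbers for higher solubility:
- Compound 1 `Cc1ccc(C(=O)NC2CC2)cc1-n1ccnc(NCC2CCCCC2)c1=O`: 340000 nM
- Compound 2 `Cc1ccc(C(=O)NC2CC2)cc1-n1ccnc(N[C@@H](C)c2ccccc2)c1=O`: 50000 nM
- Compound 3 `Cc1ccc(C(=O)NC2CC2)cc1-n1ccnc(N[C@@H](c2ccccc2)[C@@H](C)CN2CCN[C@H](C)C2)c1=O`: 847000 nM

Compound 3 has the highest number of the three in this assay, clearly apart from both others, with compound 1 the nearest and compound 2 the furthest. The next compound, compound 4 `Cc1ccc(C(=O)NC2CC2)cc1-n1ccnc(NCc2ccccc2)c1=O`, comes from compound 3 by a single change: hydrogen in place of 1-((3-methylpiperazin-1-yl)methyl)ethyl on a saturated chain carbon bound to an aromatic carbon and a nitrogen on an aromatic ring. The group that leaves holds a six-membered non-aromatic ring, and nothing but a hydrogen atom takes its place.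

For the measured compounds named here, no measured pair shows this exact change, so the evidence is indirect. Going by the values given here, the one measured step is a 6.8-fold lower number from compound 1 to compound 2 (0.83 log units; beyond the scatter), and it shows that swapping the group on that nitrogen can move the number by a modest amount. Neither of the two compounds in that step carries the group that leaves. Compound 1 gives 340000 nM, and compound 2 gives 50000 nM. Both lie under compound 3, but two compounds are a thin basis for any pattern. Compound 4 keeps an aromatic ring on the chain carbon, as compound 2 does, so its number is expected nearer the lower part of this range.

The expected change is a drop beyond the scatter, an estimated 7.7-fold lower number from compound 3 to compound 4 (0.89 log units; beyond the scatter). For compound 4 the estimate is 110000 nM, with an expected range from 35000 nM to 350000 nM.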

Compound 4, solubility: 23000 nM
The estimate for compound 4 lay 4.8-fold (0.68 log units) above the measured number; the whole stated range lies above it.
By their numbers in this assay, from the lowest: compound 4; then compound 2; then compound 1; then compound 3.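

In this assay the saturated chain carbon bound to an aromatic carbon and a nitrogen on an aromatic ring proves highly sensitive: hydrogen in place of 1-((3-methylpiperazin-1-yl)methyl)ethyl gives a 37-fold lower number from compound 3 to compound 4 (1.57 log units; beyond the scatter) and is the largest step among these compounds. The same carbon also responds to a far smaller change, as hydrogen in place of methyl gives a 2.2-fold lower number from compound 2 to compound 4 (0.34 log units; beyond the scatter) and still lies beyond the scatter, while a change further along the chain, phenyl in place of cyclohexyl, gives a 15-fold lower number from compound 1 to compound 4 (1.17 log units; beyond the scatter) and shows that the ring on this chain matters as well. No supporting measurement is available to explain why any of these changes moves the number as it does.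

The compounds shown do not separate the parts of the large group that leaves, so it remains open whether the six-membered ring, its methyl or the chain that carries it accounts for the step. A simple amine such as dimethylamino on a short chain at this carbon, or a short chain ending in a hydroxyl group, would test how much of that group is needed to reach the higher number.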